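Swapping the side chain of compound 2 for sec-butyl

The source may report more compounds than this note shows. Statements on the series, on what has been measured and on what is new or still open speak of the compounds shown alone.

Measured so far:
compound 1, `C[C@@H](O)[C@H](NC(=O)CN(c1nc(Cl)nc2[nH]cnc12)C1CC1)C(=O)OCc1ccccc1`: 12.8%
compound 2, `O=C(CN(c1nc(Cl)nc2[nH]cnc12)C1CC1)N[C@@H](CCC(=O)OCc1ccccc1)C(=O)OCc1ccccc1`: 44.5%

Both were tested in a functional assay on the whole organism (Tail, strain ICR) with Mus musculus as the target, in the tail flick test, with a stated time of 150 min, at a dose of 25 umol/kg by the oral route; a lower number here means a weaker effect, a higher number a stronger effect of the compound at the dose given. Among the compounds with values here, compound 2 stands highest of the two numbers, and its nearest neighbour is compound 1; the only step known is a number 31.7 percentage points higher from compound 1 to compound 2 (beyond the scatter).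

Compound 3, `CC[C@H](C)[C@H](NC(=O)CN(c1nc(Cl)nc2[nH]cnc12)C1CC1)C(=O)OCc1ccccc1`, has not been measured. It differs from compound 2 in one place: sec-butyl in place of 2-(benzyloxycarbonyl)ethyl on a saturated chain carbon bound to an amide-type nitrogen and a carbonyl carbon.

Within the data shown here, no measured step involves sec-butyl, so the single step from compound 1 to compound 2 is the only guide. That step showed that a change at this same carbon can move the read-out strongly, and that the large 2-(benzyloxycarbonyl)ethyl chain went with the higher number. Since compound 3 gives up that chain, a decrease is expected, though the size is uncertain because the incoming group is new; the step is estimated at a number 19.5 percentage points lower from compound 2 to compound 3 (beyond the scatter). For compound 3 the value is therefore estimated at 25%, within a range from 8% to 48%.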

Compound 3, a percentage reported as activity, at one dose (the size of the read-out at that dose, not a potency): 6.9%
Estimate against measurement, compound 3: 18.1 percentage points above; the whole stated range lies above it.
By their numbers in this assay, from the lowest: compounds 3 and 1 (each within the scatter of the next); then compound 2.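

In this assay, putting sec-butyl in place of 2-(benzyloxycarbonyl)ethyl on the saturated chain carbon bound to an amide-type nitrogen and a carbonyl carbon gives a number 37.6 percentage points lower from compound 2 to compound 3 (beyond the scatter). The two smaller side chains cannot be told apart here: ethyl in place of hydroxy gives a number 5.9 percentage points lower from compound 1 to compound 3 (within the scatter), so having a hydroxy group on this side chain or not makes no readable difference in this comparison. Among these three compounds, the higher read-out is therefore found only with the large 2-(benzyloxycarbonyl)ethyl chain, and the two compact side chains, although different in kind, stay together at the low end.

No measurement available here explains why this chain goes with the stronger effect. As far as these compounds go, it also remains open which part of the chain matters, and the answer would need comparisons such as a carboxylic acid in place of its benzyl ester, a plain benzyl side chain carrying the ring without the ester, or a longer chain of carbon only without the ring.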